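A few compounds are considered here, and "the series" means these few. Any claim that something is new, unique, unknown or untested is made for them only; others in the source may bear on it.

Working notes on the series. The common core carries a five-membered aromatic ring with two heteroatoms fused to a six-membered ring, linked through an oxygen on an aromatic ring. Compound 1 `O=C1CCCN1C1CCN(Cc2coc3cc(Oc4nc5ccccc5s4)ccc23)CC1` gives 58 nM in an in vitro assay on Sf9 cells for inhibition of leukotriene A-4 hydrolase (Homo sapiens), read by immunoassay, with stated times of 10 min and 30 min; a higher number here means a weaker inhibitor, a lower number a stronger inhibitor. Compound 2 `CC(=O)N1CC2CC1CN2Cc1cc2cc(Oc3nc4cccnc4s3)ccc2o1` gives 340 nM in this assay. Compound 3 `CC(=O)N1CC2CC1CN2Cc1coc2cc(Oc3nc4cnccc4s3)ccc12` gives 340 nM in this assay.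

Where compound 3 stands: its number is level with that of compound 2 at the digits shown, the two together being the highest of the three numbers; the nearest neighbour is compound 2, with no change at the digits shown and within the scatter, and the furthest is compound 1, whose number is lower by a step beyond the scatter.

The next compound, compound 4 `CC(=O)N1CC2CC1CN2Cc1coc2cc(Oc3nc4cccnc4s3)ccc12`, is not yet measured. It differs from compound 3 in one place: a group of 9 heavy atoms (6 carbon, 2 nitrogen, 1 sulfur; one five-membered aromatic ring with 2 hetero atoms, one six-membered aromatic ring with 1 hetero atom) in place of a group of 9 heavy atoms (6 carbon, 2 nitrogen, 1 sulfur; one five-membered aromatic ring with 2 hetero atoms, one six-membered aromatic ring with 1 hetero atom), on an oxygen on an aromatic ring. The two have the same atoms, joined differently. Among the measured compounds shown here, no measured pair isolates this rearrangement, so the size of its effect is unknown.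

Compound 4 is expected to give about 350 nM in this assay, with a range from 150 nM to 800 nM. The expected step from compound 3 to compound 4 is a 1.0-fold higher number from compound 3 to compound 4 (0.01 log units; within the scatter), no change beyond the scatter.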

Compound 4, half-maximal inhibitory concentration: 300 nM
The estimate for compound 4 lay 1.2-fold (0.07 log units) above the measured number; the range from low to high includes it.
By their numbers in this assay, from the lowest: compound 1; then compounds 4, 2 and 3 (each within the scatter of the next).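

In this assay, among the compounds shown here, the only pair that isolates this rearrangement gives a 1.1-fold lower number from compound 3 to compound 4 (0.05 log units; within the scatter). At this place, on an oxygen on an aromatic ring, the two ways of joining the same atoms therefore cannot be told apart, and this holds for this pair alone, with the rest of the molecule kept as in compound 3. No supporting measurement bears on this result, so nothing can be said about why the rearrangement leaves the number within the scatter.

Compound 1, at 58 nM, differs from compound 3 and compound 4 in more than one place, so its gap to them cannot be assigned to the group on the oxygen or to any other single part of the molecule. As far as these compounds go, it also remains open how a different group on that oxygen, such as a simple phenyl or pyridine ring, or a methoxy group or an amine added to the present group, would read in this assay.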